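One ring swapped, one number still unknown

This account rests on a few compounds, and the source may have more. Where it says the series, first, only, none or still open, it means among the compounds named here.

Within the data shown here, in an ADME assay on microsomes from liver (Rattus norvegicus) for metabolic stability, read by LC-MS, using NADPH, with a stated time of 60 min, tested at 0.1 uM (on this read-out higher numbers stand for a more stable compound and lower numbers for a less stable compound), compound 1 `Fc1ccc(Nc2cc3[nH]c(Nc4ccc(N5CCNCC5)cn4)nc3cn2)cc1C(F)(F)F` gives 59%, while compound 2 `Fc1ccc(Nc2cc3[nH]c(Nc4ccc(N5CCN(CC6CC6)CC5)cn4)nc3cn2)cc1C(F)(F)F` gives 36%, the lower of the two numbers so far. Among the measured compounds shown here, the only measured step is a number 23 percentage points lower from compound 1 to compound 2 (beyond the scatter), and it came with cyclopropylmethyl in place of hydrogen on an amine nitrogen in a ring.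

Compound 3 `C[C@@H]1CN(c2ccc(Nc3nc4cnc(Nc5ccc(F)c(C(F)(F)F)c5)cc4[nH]3)nc2)C[C@H](C)O1` keeps the shared core but has 2,6-dimethylmorpholin-4-yl in place of 4-(cyclopropylmethyl)piperazin-1-yl on an aromatic carbon. For the measured compounds named here, the measured step bears on this only in part: compound 3 also lacks cyclopropylmethyl, but no measured compound carries its new ring. A smaller upward step than the measured one is therefore expected in this assay, and the estimate is a number 12 percentage points higher from compound 2 to compound 3 (beyond the scatter). The expected value for compound 3 is 48%, within an estimated range of 25% to 70%.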

Compound 3, percent of the compound remaining: 19%
Compound 3: middle estimate off by 29 percentage points, on the high side; measured number below the stated range.
By their numbers in this assay, from the lowest: compound 3; then compound 2; then compound 1.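

In this assay, placing 2,6-dimethylmorpholin-4-yl on the aromatic carbon in place of 4-(cyclopropylmethyl)piperazin-1-yl gives a number 17 percentage points lower from compound 2 to compound 3 (beyond the scatter), so losing cyclopropylmethyl does not by itself bring a higher number at this position. Set against the plain piperazin-1-yl, the same group gives a number 40 percentage points lower from compound 1 to compound 3 (beyond the scatter), which leaves compound 3 with the lowest number of the three and makes this the largest step seen here. The identity of the ring at this position therefore counts, not just what is attached to a piperazine nitrogen.

Nothing shown here explains why the number falls with either change. From the compounds shown here alone, it also remains open whether a plain morpholin-4-yl, without the two methyl groups, or a 4-methylpiperazin-1-yl would come closer to compound 1.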